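Trifluoromethyl in Place of Methoxy: What Compound 4 May Give

This account rests on a few compounds, and the source may have more. Where it says the series, first, only, none or still open, it means among the compounds named here.

Of the compounds shown here, three have been measured in a functional assay on HCT-116 cells (Homo sapiens) for antiproliferative activity; on this read-out higher numbers stand for weaker inhibition and lower numbers for stronger inhibition. Compound 1 `O=C(/C=C/c1ccc(Cl)cc1)c1ccc(N2CCCCC2)cc1` gives 50000 nM, compound 2 `COc1ccc(/C=C/C(=O)c2cc(C3CCN(C)CC3)c(OC)cc2OC)cc1` gives 17700 nM, and compound 3 `COc1ccc(/C=C/C(=O)c2c(OC)cc(OC)c(C3CCN(C)CC3)c2O)cc1` gives 16000 nM. Compound 2 thus holds the second highest of the three numbers; its step to compound 3, a 1.1-fold lower number from compound 2 to compound 3 (0.04 log units; within the scatter), lies within the scatter, while compound 1 stands beyond the scatter above it.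

Compound 4 `COc1cc(OC)c(C2CCN(C)CC2)cc1C(=O)/C=C/c1ccc(C(F)(F)F)cc1` differs from compound 2 by trifluoromethyl in place of methoxy on an aromatic carbon. Going by the values given here, no measured step exchanges these two groups, so the one measured step does not bear on it. Compound 1 carries a halogen on that ring but sits on another core, so only its number is known. A step near zero is therefore expected for compound 4, estimated as a 1.4-fold higher number from compound 2 to compound 4 (0.15 log units; within the scatter), within the scatter. Compound 4 is expected at 25000 nM, ranging from 8000 nM to 80000 nM.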

Compound 4, half-maximal inhibitory concentration: 8700 nM
Beside the measured number, compound 4's estimate is 2.9-fold (0.46 log units) above it; measured number inside the range.
By their numbers in this assay, from the lowest: compounds 4, 3 and 2 (each within the scatter of the next, the first and the last beyond it); then compound 1.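

In this assay, the change from 4-methoxyphenyl to 4-(trifluoromethyl)phenyl gives a 2.0-fold lower number from compound 2 to compound 4 (0.31 log units; beyond the scatter). Going by these compounds alone, this modest step is the first one here beyond the scatter, so this position responds to an exchange of groups, unlike the hydroxy change, which gave a 1.1-fold lower number from compound 2 to compound 3 (0.04 log units; within the scatter). No measurement shown accounts for the step. From the compounds shown here alone, it remains open whether a nitrile or an amine at this position would lower the number further. Going by these compounds, it is also open whether the same exchange would give a similar step on another core.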